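The compounds below may be only part of what the source reports. "The series", "measured", "known", "first", "only" and "open" are said of these compounds alone.

Measured compounds:
Compound 1 `CCn1c(-c2cnc(C)nc2)nc2c(N[C@H]3CCN(C(=O)C4CCC4)C3)ncnc21`; in an ADME assay (Rattus norvegicus, strain Wistar Han) for pharmacokinetics (a lower number here means that more of the compound stays in the plasma, a higher number that more of the compound sits outside the plasma), compound 1 gives 0.5 L/kg.
Compound 2 `CCn1c(-c2cnc(C)nc2)nc2c(O[C@H]3CCN(C(=O)C4CC(F)(F)C4)C3)ncnc21`; in this assay compound 2 gives 0.5 L/kg.

Compound 1 and compound 2 stand level at the digits shown in this assay; the two values lie within the scatter of each other, so the pair shows no change, and neither compound can be called higher or lower than the other. Going by the values given here, no step between compounds differing in a single place has been measured, so the series holds no direct precedent for a change at the carbonyl carbon.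

Compound 3 `CCn1c(-c2cnc(C)nc2)nc2c(N[C@H]3CCN(C(=O)C4CC4)C3)ncnc21` is the next compound, not yet measured in this assay. Relative to compound 1 it differs in one place: cyclopropyl in place of cyclobutyl on a carbonyl carbon. The change is modest, one four-membered non-aromatic ring of carbon only giving way to one three-membered non-aromatic ring of carbon only, with no hydrogen-bond donors or acceptors and no net charge on either side. Among the compounds with values here, with only two measured values, both level, the expectation is a step of no size beyond the scatter, in no preferred direction. Compound 3 is expected to give about 0.5 L/kg in this assay, with a range from 0.3 L/kg to 0.9 L/kg. The step of no change at the digits printed from compound 1 to compound 3 (within the scatter) is expected to lie within the scatter.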

Compound 3, volume of distribution: 1 L/kg
Compound 3: middle estimate off by 2.0-fold (0.30 log units), on the low side, and the stated range ends below it.
By their numbers in this assay, from the lowest: compounds 1, 2 and 3 (each within the scatter of the next).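

In this assay, cyclopropyl in place of cyclobutyl on a carbonyl carbon, whose other neighbour is an amide-type nitrogen in a ring, gives a 2.0-fold higher number from compound 1 to compound 3 (0.30 log units; within the scatter), the first single-place step available in this series. As this step lies within the scatter, this one exchange at this position shows no readable effect, and no direction can be assigned to it from this pair alone. Nothing on hand explains the step or shows what lies behind the gap between the two printed values.

Still open, on these data alone, is how the same position responds to groups further from these two small carbon rings, such as a longer alkyl chain, a phenyl ring or a group carrying an amine. As far as these compounds go, compound 2 differs from compound 1 in more than one place, so whether the exchange of cyclobutyl-type ring for cyclopropyl would read the same on the structure of compound 2 also remains open.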